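A few compounds are considered here, and "the series" means these few. Any claim that something is new, unique, unknown or untested is made for them only; others in the source may bear on it.

Two compounds of this series carry numbers in a functional assay on PC-3 cells (Homo sapiens) for antiproliferative activity, read by MTT assay, with a stated time of 24 h (on this read-out lower numbers stand for stronger inhibition and higher numbers for weaker inhibition), so far. Compound 1 `O=C1O/C(=C\Cn2cc(Cc3ccccc3)nn2)C(OCc2ccccc2)=C1OCc1ccccc1` gives 71300 nM in this assay. Compound 2 `O=C1NC(O)(CCn2cc(C3=CCCCC3)nn2)C(OCc2ccccc2)=C1OCc1ccccc1` gives 67200 nM in this assay. Compound 1 holds the highest of the two numbers, yet its nearest neighbour, compound 2, sits within the scatter, so the two values show no readable difference; both stand at weak inhibition. Among the measured compounds shown here, no step between two measured compounds that differ in a single place is available, and compound 2 differs from compound 1 in several places at once, so no single change has a measured effect to draw on.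

Compound 3 `CC(C)(C)c1ccc(-c2cn(C/C=C3\OC(=O)C(OCc4ccccc4)=C3OCc3ccccc3)nn2)cc1` has not been measured. Its change from compound 1: 4-(tert-butyl)phenyl in place of benzyl on an aromatic carbon. With nothing measured that bears on this change, the working expectation is a number close to that of compound 1. The step of a 1.4-fold lower number from compound 1 to compound 3 (0.15 log units; within the scatter) is expected, not beyond the scatter in either direction. Compound 3 is estimated at 50000 nM in this assay, with a range from 15000 nM to 150000 nM.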

Compound 3, half-maximal inhibitory concentration: > 100000 nM
Compound 3: only a limit was reported; the forecaster's own chance of this, stated with the estimate: 15%; middle value at least 2.0-fold (0.30 log units) away from the limit.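

In this assay compound 3 carries a limit and not a number: the limit of > 100000 nM in this assay, at which 1 of the 3 values shown sits. As far as these compounds go, the step reads an at least 1.4-fold higher number from compound 1 to compound 3 (0.14 log units; that floor lies within the scatter), so the floor of this change cannot be told apart from compound 1, and how far the true value lies beyond that floor stays unknown. Among the compounds shown here, this is the first single-place change on this aromatic carbon of the five-membered ring with 3 nitrogen, and going from benzyl to 4-(tert-butyl)phenyl, a larger all-carbon group with one six-membered aromatic ring, gives no sign of stronger inhibition.

The step swaps the whole group at once, so the part played by the tert-butyl cannot be separated from that of the aryl group itself; an unsubstituted phenyl at this position would divide the two. Whether any group here can move the number toward stronger inhibition also stays open, and a phenyl carrying an amine or a carboxylic acid in place of the tert-butyl would test a different kind of substituent from the all-carbon groups shown so far.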